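The source may report more compounds than this note shows. Statements on the series, on what has been measured and on what is new or still open speak of the compounds shown alone.

Working notes on the series. Compound 3 `CCCNCc1ccc(-c2c3ncn(CC4(O)CCN(Cc5ccc(-c6ccco6)cc5Cl)CC4)c(=O)c3nn2C)cc1` stands lowest of the three numbers in an assay on isolated protein for inhibition of ubiquitin carboxyl-terminal hydrolase 7 (Homo sapiens), with stated times of 30 min and 2 h (a lower number here means a stronger inhibitor, a higher number a weaker inhibitor), at 43.9 nM; compound 1 `Cn1nc2c(=O)n(CC3(O)CCN(Cc4ccc(-c5ccco5)cc4Cl)CC3)cnc2c1-c1ccc(Cl)cc1` gives 143 nM and compound 2 `Cn1nc2c(=O)n(CC3(O)CCN(Cc4ccc(-c5ccco5)cc4Cl)CC3)cnc2c1-c1ccc(C(F)(F)F)cc1` gives 530 nM. The two steps onto compound 3 were a 3.3-fold lower number from compound 1 to compound 3 (0.51 log units; beyond the scatter) and a 12-fold lower number from compound 2 to compound 3 (1.08 log units; beyond the scatter), while a 3.7-fold higher number from compound 1 to compound 2 (0.57 log units; beyond the scatter) links the other two. Compound 4 `CC(=O)NCc1ccc(-c2c3ncn(CC4(O)CCN(Cc5ccc(-c6ccco6)cc5Cl)CC4)c(=O)c3nn2C)cc1` carries acetyl in place of propyl on an amine nitrogen. Going by the values given here, no measured step exchanges groups on that amine nitrogen; the steps into compound 3 replaced a chloro or trifluoromethyl on an aromatic carbon, so they only fix the starting point. A modest weakening step is expected in this assay, with direction uncertain, and compound 4 is estimated at 85 nM, within 20 nM to 350 nM. That expectation means a 1.9-fold higher number from compound 3 to compound 4 (0.29 log units; within the scatter).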

Compound 4, half-maximal inhibitory concentration: 46.1 nM
For compound 4 the middle estimate is 1.8-fold (0.27 log units) above the measured one; low and high end bracket the measured number.
By their numbers in this assay, from the lowest: compounds 3 and 4 (each within the scatter of the next); then compound 1; then compound 2.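

In this assay, going by these compounds alone, acetyl in place of propyl on the amine nitrogen gives a 1.1-fold higher number from compound 3 to compound 4 (0.02 log units; within the scatter), so this is the first evidence that this nitrogen tolerates an exchange of propyl for acetyl without a readable shift. The acetamidomethyl group keeps the advantage seen with (propylamino)methyl, with a 3.1-fold lower number from compound 1 to compound 4 (0.49 log units; beyond the scatter) and an 11-fold lower number from compound 2 to compound 4 (1.06 log units; beyond the scatter). Nothing available explains why the two groups read alike. Open, from the compounds shown here alone, is whether the unsubstituted amine, a longer chain or a sulfonyl group on this nitrogen would read the same.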